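The source may report more compounds than this note shows. Statements on the series, on what has been measured and on what is new or still open speak of the compounds shown alone.

Series notes. For the measured compounds named here, every value measured so far in an ADME assay on CEM-SS cells (Homo sapiens) for cytotoxicity, read by XTT assay (a lower number here means that less compound is tolerated, a higher number that more compound is tolerated), is a limit rather than a number. Compound 1 `CN(O)C(=O)c1cc2c(CN3CCC(O)C3)cn(Cc3ccc(F)cc3)c2cn1` gives a limit of > 100000 nM. Compound 2 `CN(O)C(=O)c1cc2c(CO)cn(Cc3ccc(F)cc3)c2cn1` gives a limit of > 266000 nM. Compound 3 `COCCOCc1cn(Cc2ccc(F)cc2)c2cnc(C(=O)N(C)O)cc12` gives a limit of > 100000 nM. The set thus rests on the limit of > 100000 nM in this assay, at which 2 of the 3 values shown sit, and on (the limit of > 266000 nM in this assay, at which 1 of the 3 values shown sits), and nothing places compound 3 anywhere but at the ceiling. The steps a step that the two limits leave unreadable from compound 1 to compound 3, a step that the two limits leave unreadable from compound 2 to compound 3 and a step that the two limits leave unreadable from compound 1 to compound 2 are all left unreadable by those limits. Compound 4 `COCCOCCCc1cn(Cc2ccc(F)cc2)c2cnc(C(=O)N(C)O)cc12` differs from compound 3 by 2-(2-methoxyethoxy)ethyl in place of 2-methoxyethoxy on a saturated chain carbon bound to an aromatic carbon. With no readable step to lean on, the expectation is for compound 4 to stay at the ceiling, an estimated step that the limit leaves unreadable from compound 3 to compound 4 of nothing beyond the scatter. Compound 4 is therefore estimated at 150000 nM, with a range from 60000 nM to 400000 nM.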

Compound 4, half-maximal cytotoxic concentration: > 10000 nM
Compound 4: only a limit was reported; the forecaster's own chance of this, stated with the estimate: 85%; the middle value lies beyond the limit too.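

In this assay compound 4 gives > 10000 nM, which is a limit. Its steps to compound 1, compound 2 and compound 3 cannot be read, as all four values are limits. The compounds shown leave open whether any of these chain changes shifts tolerated concentration in this assay.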